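Methyl in Place of Hydrogen on Two Fused Cores

The source may report more compounds than this note shows. Statements on the series, on what has been measured and on what is new or still open speak of the compounds shown alone.

Compound 1 `CCOC(=O)CSc1nncc2cnc(C)n12` carries an (ethoxycarbonyl)methyl on a sulfur; in a functional assay for inhibition, with Homo sapiens as the target (on this read-out higher numbers stand for weaker inhibition and lower numbers for stronger inhibition), compound 1 gives 52000 nM. Compound 3 `CCOC(=O)CSc1nncc2c(C)nc(C)n12` differs from it by methyl in place of hydrogen on an aromatic carbon. In this assay compound 3 reaches only a limit, > 48000 nM. The step that the limit leaves unreadable from compound 1 to compound 3 therefore cannot be sized. Compound 2 `Cc1nc(C)n2c(S)nncc12` rests on another core; the difference between the two cores is not broken down here. In this assay compound 2 also gives only a limit, > 48000 nM. The step that the two limits leave unreadable from compound 2 to compound 3 is equally unreadable because two of the three values sit at the limit of > 48000 nM in this assay, at which 2 of the 3 values shown sit. Compound 4 `Cc1nnc(S)n2c(C)nc(C)c12` differs from compound 2 by methyl in place of hydrogen on an aromatic carbon, the same kind of change as from compound 1 to compound 3, though here the place is on a six-membered aromatic ring with 3 nitrogen, para to a sulfanyl group, rather than on a five-membered aromatic ring with 2 nitrogen. Beside the unreadable earlier step, the step that the limit leaves unreadable from compound 2 to compound 4 is expected to be small. That expectation rests on compound 1, which gives 52000 nM, and on the weak inhibition seen throughout. Compound 4 is estimated at 60000 nM, between 30000 nM and 200000 nM.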

Compound 4, half-maximal inhibitory concentration: > 48000 nM
Compound 4 was reported as a limit; the forecaster's own chance of this, stated with the estimate: 80%; the middle value is on the limit's open side.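

In this assay, going by these compounds alone, compound 4 reaches only a limit, > 48000 nM, so no step from compound 2 to compound 4 can be read. The compounds shown leave open whether methyl in place of hydrogen on an aromatic carbon changes inhibition on either core, as most values sit at one limit: the limit of > 48000 nM in this assay, at which 3 of the 4 values shown sit.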